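The source may report more compounds than this note shows. Statements on the series, on what has been measured and on what is new or still open speak of the compounds shown alone.

Measured in a functional assay on MT4 cells (Homo sapiens) for cytotoxicity, read by MTT assay; on this read-out lower numbers stand for higher toxicity in this test and higher numbers for lower toxicity in this test:
Compound 1 `Cc1c(O)nc(Sc2ccc(F)cc2F)nc1Cc1c(F)cccc1F`: > 65800 nM, a limit.
Compound 2 `Cc1c(O)nc(Sc2ccccc2)nc1Cc1c(F)cccc1F`: > 72700 nM, a limit.

Among the compounds with values here, compound 2 stands only at a limit, as does the one other measured compound, so no number places it. Compound 3 `Cc1c(O)nc(Sc2ccccc2)nc1Cc1c(Cl)cccc1Cl` differs from it by 2,6-dichlorophenyl in place of 2,6-difluorophenyl on a saturated chain carbon bound to an aromatic carbon. Within the data shown here, the only measured step, a step that the two limits leave unreadable from compound 1 to compound 2, lies on a sulfur rather than at this place and gives no size. No step beyond the scatter is therefore expected in this assay, and no direction can be assigned. The expected change is an at least 1.1-fold lower number from compound 2 to compound 3 (0.06 log units; that floor lies within the scatter). Compound 3 is estimated at 62000 nM, with an expected range of 20000 nM to 90000 nM.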

Compound 3, half-maximal cytotoxic concentration: > 66300 nM
Compound 3 was reported as a limit; the forecaster's own chance of this, stated with the estimate: 70%; at least 1.0-fold (0.02 log units) between middle value and limit.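

Within the data shown here, compound 2 and compound 3 both stand only as limits in this assay, so no step between them can be read. The compounds shown leave open whether 2,6-dichlorophenyl in place of 2,6-difluorophenyl changes this read-out at all.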